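The source may report more compounds than this note shows. Statements on the series, on what has been measured and on what is new or still open speak of the compounds shown alone.

Working notes on the series.

Within the data shown here, compound 1 `CCOc1ccc(-c2c(NC(=O)c3ccc(OC(C)C)cc3)c(C(=O)O)nn2-c2ccc(Oc3ccccc3)cc2)cc1` carries the lowest of the two numbers so far in an assay for displacement of a labelled ligand from E3 ubiquitin-protein ligase Mdm2 (Homo sapiens), read by fluorescence polarization, with a stated time of 30 min (on this read-out lower numbers stand for stronger inhibition and higher numbers for weaker inhibition), where compound 1 gives 301 nM. Its closest neighbour is compound 2 `CCOc1ccc(-c2c(NC(=O)c3ccc(OCC(C)C)cc3)c(C(=O)O)nn2-c2ccc(Oc3ccccc3)cc2)cc1`, which in this assay gives 446 nM. Among the measured compounds shown here, the only step measured so far, a 1.5-fold higher number from compound 1 to compound 2 (0.17 log units; within the scatter), moves the chain on the oxygen on the aromatic ring of the amide-side ring and stays within the scatter, so the two compounds cannot be ranked against each other.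

Compound 3 `CC(C)Oc1ccc(C(=O)Nc2c(C(=O)O)nn(-c3ccc(Oc4ccccc4)cc3)c2-c2ccc(OCc3ccccc3)cc2)cc1` differs from compound 1 by phenyl in place of methyl on a saturated chain carbon bound to an oxygen on an aromatic ring. For the measured compounds named here, no measured step touches this chain: the step of a 1.5-fold higher number from compound 1 to compound 2 (0.17 log units; within the scatter) concerns a different oxygen-bound chain and, being within the scatter, gives neither a direction nor a size to carry over. Going by the values given here, the change therefore has no precedent, and the expectation rests on compound 1 alone, with a wide range to reflect that.

For compound 3 in this assay the expected step from compound 1 is a 1.3-fold higher number from compound 1 to compound 3 (0.12 log units; within the scatter). The estimate for compound 3 is 400 nM, with a range from 120 nM to 1300 nM.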

Compound 3, inhibition constant: 4470 nM
Compound 3: the middle estimate sits 11-fold (1.05 log units) below what was measured; the whole stated range lies below it.
By their numbers in this assay, from the lowest: compounds 1 and 2 (each within the scatter of the next); then compound 3.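

In this assay, among these compounds, the change from ethoxy to benzyloxy gives a 15-fold higher number from compound 1 to compound 3 (1.17 log units; beyond the scatter) and is the first step beyond the scatter, whereas a 1.5-fold higher number from compound 1 to compound 2 (0.17 log units; within the scatter) stays within it, so the read-out can respond strongly to the chain on this oxygen on an aromatic ring. The entering phenyl and the leaving methyl carry no hydrogen-bond donor, hydrogen-bond acceptor or net charge, so a large step here occurs with a change in carbon atoms and an added aromatic ring alone. Nothing at hand accounts for the size of this step.

The compounds shown have only ethoxy and benzyloxy at this place, so it remains open whether a methoxy, a propoxy or a longer chain would stay close to compound 1 or move toward compound 3, and whether a cyclohexylmethoxy would behave as the benzyloxy does. As far as these compounds go, it also remains open whether the same change would give a step of similar size with the isobutyl of compound 2 on the other oxygen.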